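The source may hold more compounds than are shown below. What is called first, only, known or untested is meant among the compounds shown, and "the series" means these compounds.

The measured compounds in an ADME assay on Vero cells (Chlorocebus sabaeus) for cytotoxicity, read by MTT assay, with a stated time of 72 h; on this read-out higher numbers stand for lower toxicity in this test and lower numbers for higher toxicity in this test:

Compound 1 `COC(=O)c1cc(-c2cccc(NC(=O)c3ccc(/C=C/C(=O)c4cccnc4)cc3)c2)on1` gave "not determined" (no result reported).

Compound 2 `COC(=O)c1cc(-c2cccc(NC(=O)c3ccc(/C=C/C(=O)c4ccc(C)c([N+](=O)[O-])c4)cc3)c2)on1` gave > 80 ug/mL, which is a limit of the assay and not a number.

Compound 3 `COC(=O)c1cc(-c2cccc(NC(=O)c3ccc(/C=C/C(=O)c4ccc(F)cc4F)cc3)c2)on1` gave > 40 ug/mL, again a limit of the assay rather than a number.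

Compound 3 therefore stands only at a limit in this assay. No single number is known for it, one other compound sits at a different limit, and compound 1 has no result at all. Among the measured compounds shown here, the only measured step is a step that the two limits leave unreadable from compound 2 to compound 3. Both of its ends are limits, and its size cannot be read in either direction.

Compound 4 `COC(=O)c1cc(-c2cccc(NC(=O)c3ccc(/C=C/C(=O)c4ccc(C)cc4)cc3)c2)on1` differs from compound 3 in one place: 4-methylphenyl in place of 2,4-difluorophenyl on a carbonyl carbon. For the measured compounds named here, the one measured step that touches this position is a step that the two limits leave unreadable from compound 2 to compound 3, and it gives no usable size. Two of the three values shown sit at limits, the limit of > 40 ug/mL in this assay, at which 1 of the 3 values shown sits, and (the limit of > 80 ug/mL in this assay, at which 1 of the 3 values shown sits), and compound 1 has none. With nothing readable to build on, the change to compound 4 is not expected to move the result beyond the usual scatter. For compound 4 the expected step is therefore a step that the limit leaves unreadable from compound 3 to compound 4. Compound 4 is thus estimated at 60 ug/mL, with a range from 25 ug/mL to 120 ug/mL, and a fair chance that the assay again reports only a limit.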

Compound 4, half-maximal cytotoxic concentration: > 80 ug/mL
Compound 4 ended at the assay's limit; the forecaster's own chance of this, stated with the estimate: 60%; at least 1.3-fold (0.12 log units) between middle value and limit.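

In this assay compound 4 gives > 80 ug/mL, which is a limit of the assay and not a number. Compound 2 and compound 3 also stand only at limits, so the steps linking them to compound 4 cannot be read. The compounds shown leave open how far any of these changes moves the half-maximal cytotoxic concentration.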